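Aryl exchange at one carbon of the shared core

A few compounds are considered here, and "the series" means these few. Any claim that something is new, unique, unknown or untested is made for them only; others in the source may bear on it.

- compound 1 `COc1cc(-c2ccnc3cc(-c4cccc(C#N)c4)nn23)cc(OC)c1OC`: > 10000 nM (a limit)
- compound 2 `COc1cc(-c2ccnc3cc(-c4ccc5ccn(C)c5c4)nn23)cc(OC)c1OC`: 187 nM
- compound 3 `COc1ccc(-c2cc3nccc(-c4cc(OC)c(OC)c(OC)c4)n3n2)cc1F`: not yet measured

Among the measured compounds shown here, in a functional assay on HeLa cells (Homo sapiens) for inhibition, read by CCK-8 assay, with a stated time of 48 h (a lower number here means a stronger inhibitor, a higher number a weaker inhibitor), compound 2 gives 187 nM, the only actual number so far. Compound 1 gives > 10000 nM, which is a limit of the assay. The next change is 3-fluoro-4-methoxyphenyl in place of 1-methyl-1H-indol-6-yl on an aromatic carbon. For the measured compounds named here, one measured step bears on it: an at least 53-fold lower number from compound 1 to compound 2 (1.72 log units; beyond the scatter). This large step lies at the same aromatic carbon, so the group there can move the read-out strongly. It does not measure the entering group, however, and compound 3 has not been compared with any close analogue. Given an at least 53-fold lower number from compound 1 to compound 2 (1.72 log units; beyond the scatter), a higher number is expected in this assay, beyond the scatter but of moderate size. The expected change is a 3.7-fold higher number from compound 2 to compound 3 (0.57 log units; beyond the scatter). For compound 3 the estimated value is 700 nM, with an expected range of 120 nM to 4500 nM.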

Compound 3, half-maximal inhibitory concentration: 236 nM
Compound 3: middle estimate off by 3.0-fold (0.47 log units), on the high side; low and high end bracket the measured number.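

In this assay, 3-fluoro-4-methoxyphenyl in place of 1-methyl-1H-indol-6-yl gives a 1.3-fold higher number from compound 2 to compound 3 (0.10 log units; within the scatter), so the two groups cannot be told apart here and a five-membered aromatic ring in the group is not required at this carbon. The strong dependence on the group at this carbon also holds among groups with a single six-membered aromatic ring: an at least 42-fold lower number from compound 1 to compound 3 (1.62 log units; beyond the scatter) separates 3-cyanophenyl from 3-fluoro-4-methoxyphenyl, so the weak result for compound 1 does not simply reflect the absence of the indole. The value of compound 1 is a limit, which makes the size of that step a bound only: the limit of > 10000 nM in this assay, at which 1 of the 3 values shown sits.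

From the compounds shown here alone, it remains open whether the fluorine, the methoxy or the two together account for the difference from 3-cyanophenyl, which a plain 3-fluorophenyl or 4-methoxyphenyl group could separate. Going by these compounds, how this carbon responds to a phenyl bearing an amine or a carboxylic acid is also open.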